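The source may report more compounds than this note shows. Statements on the series, on what has been measured and on what is new or still open speak of the compounds shown alone.

Measured compounds:
- compound 2, `Cc1ccc(CNC(=O)c2cccc(C(C)Oc3cccnc3Nc3ncc(C)s3)c2)cc1`: 8500 nM
- compound 1, `CC(Oc1cccnc1Nc1cnn(C)c1)c1cccc(C(=O)NCc2ccc(F)c(Cl)c2)c1`: 35700 nM

In a functional assay on NCI-H3122 cells (Homo sapiens) for antiproliferative activity, read by MTT assay, with a stated time of 48 h (on this read-out higher numbers stand for weaker inhibition and lower numbers for stronger inhibition), compound 2 gives 8500 nM, the lower of the two numbers available. Within the data shown here, compound 1, which carries a different substituent on the aminopyridine part of the shared core, gives 35700 nM in this assay, and the gap between the two lies beyond the usual scatter; no single-point step connects them, so the two values can only be set side by side.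

Compound 3, `Cc1cnc(Nc2ncccc2OC(C)c2cccc(C(=O)NCc3ccc(F)c(Cl)c3)c2)s1`, is the not yet measured analogue of compound 2. It differs from compound 2 in one place: 3-chloro-4-fluorophenyl in place of 4-methylphenyl on a saturated chain carbon bound to an amide-type nitrogen. Compound 1 carries this same benzyl group but also differs elsewhere, so its value cannot be read as the effect of the change alone.

Among the measured compounds shown here, with no matched step available, the expectation is a modest move in this assay, if any, in either direction but more plausibly toward weaker inhibition given that compound 1 with the same benzyl group shows 35700 nM. The estimated step from compound 2 to compound 3 is a 1.4-fold higher number from compound 2 to compound 3 (0.15 log units; within the scatter). Compound 3 is therefore expected to give about 12000 nM, within a range from 3500 nM to 40000 nM.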

Compound 3, half-maximal inhibitory concentration: 8200 nM
Compound 3: the middle estimate sits 1.5-fold (0.17 log units) above what was measured; measured number inside the range.
By their numbers in this assay, from the lowest: compounds 3 and 2 (each within the scatter of the next); then compound 1.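

In this assay the exchange of 4-methylphenyl for 3-chloro-4-fluorophenyl on a saturated chain carbon bound to an amide-type nitrogen amounts to a 1.0-fold lower number from compound 2 to compound 3 (0.02 log units; within the scatter) and so leaves the read-out at this position within the scatter, something the earlier pair could not show, as compound 1 and compound 2 differ in more than one place. With the 3-chloro-4-fluorobenzyl group held constant, 5-methyl-1,3-thiazol-2-yl in place of 1-methyl-1H-pyrazol-4-yl on a nitrogen on an aromatic ring gives a 4.4-fold lower number from compound 1 to compound 3 (0.64 log units; beyond the scatter) and is the only one of the two single changes that lies beyond the scatter, a finding that rests on this one pair. Nothing available explains either result.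

The compounds shown leave open whether the position on the chain carbon would accept a group of another kind, such as a cyclohexyl ring, a carboxylic acid or an amine, as readily as these two substituted phenyl rings. They also leave open whether the same exchange of the phenyl groups would read alike with 1-methyl-1H-pyrazol-4-yl on the nitrogen.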